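The compounds below may be only part of what the source reports. "The series", "measured", "known", "first", "only" and "open" are said of these compounds alone.

In a functional assay on K562 cells (Homo sapiens) for inhibition (on this read-out higher numbers stand for weaker inhibition and lower numbers for stronger inhibition), compound 1 (`CC(=O)/C=C/c1ccc([N+](=O)[O-])cc1`) gives 2600 nM and compound 2 (`CC(=O)/C=C/c1ccc(Br)cc1`) gives 5600 nM as the higher number of the two. Compound 3 (`CC(=O)/C=C/c1ccc(Br)cc1F`) keeps the bromo group of compound 2 and adds fluoro in place of hydrogen on an aromatic carbon. Going by the values given here, the sole measured step (a 2.2-fold higher number from compound 1 to compound 2 (0.33 log units; beyond the scatter)) exchanged a different group and was modest, so it bears only loosely on this change, and no shift beyond the scatter is expected in this assay. The estimated step (a 1.2-fold lower number from compound 2 to compound 3 (0.09 log units; within the scatter)) stays within that expectation. For compound 3 the expected value is 4500 nM with an estimated range from 1800 nM to 11000 nM in this read-out.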

Compound 3, half-maximal inhibitory concentration: 7400 nM
For compound 3 the middle estimate is 1.6-fold (0.22 log units) below the measured one, within the range that was stated.
By their numbers in this assay, from the lowest: compound 1; then compounds 2 and 3 (each within the scatter of the next).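

In this assay, adding fluoro ortho to a group of 5 heavy atoms and meta to the bromo group gives a 1.3-fold higher number from compound 2 to compound 3 (0.12 log units; within the scatter), so this aromatic carbon accepts fluoro without a shift beyond the scatter. The earlier step exchanged one group at a single place, whereas this one shows a substitution at a second aromatic carbon. No available evidence explains this result.

As far as these compounds go, whether an amine or a methoxy group on this same carbon would also stay within the scatter of compound 2 remains open. So does whether fluoro here would behave alike with the nitro group of compound 1 in place of bromo.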